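The compounds below may be only part of what the source reports. "The series", "measured", "known", "first", "only" and "open" are said of these compounds alone.

Measured compounds:
compound 1, `COc1nc2ccccc2cc1/C=C/c1noc(-c2ccccc2C)n1` — in an ADME assay on HepG2 cells (Homo sapiens) for cytotoxicity, read by sulforhodamine B assay, with a stated time of 48 h (a higher number here means that more compound is tolerated, a lower number that less compound is tolerated), compound 1 gives only a limit, > 230000 nM.
compound 2, `COc1ccccc1-c1nc(/C=C/c2cc3ccccc3nc2OC)no1` — in this assay compound 2 gives only a limit, > 220000 nM.
compound 3, `COc1nc2ccccc2cc1/C=C/c1noc(-c2cccc(C)c2)n1` — in this assay compound 3 gives only a limit, > 230000 nM.

All three measured compounds share a core and differ only in the phenyl group on the five-membered ring. Compound 1 carries a 2-methylphenyl, compound 2 a 2-methoxyphenyl, compound 3 a 3-methylphenyl. The change from compound 1 to compound 2 is methoxy in place of methyl on an aromatic carbon and gives a step that the two limits leave unreadable from compound 1 to compound 2. The difference between the cores of compound 1 and compound 3 is 3-methylphenyl in place of 2-methylphenyl on an aromatic carbon, with a step that the two limits leave unreadable from compound 1 to compound 3. From compound 2 to compound 3 the step is a step that the two limits leave unreadable from compound 2 to compound 3. None of these steps can be read, since every value sits at a limit: the limit of > 220000 nM in this assay, at which 1 of the 3 values shown sits, and (the limit of > 230000 nM in this assay, at which 2 of the 3 values shown sit).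

Compound 4, `COc1cccc(-c2nc(/C=C/c3cc4ccccc4nc3OC)no2)c1`, is not yet measured. It differs from compound 3 by methoxy in place of methyl on an aromatic carbon. This is the same kind of change as that from compound 1 to compound 2, though not the same: there the methoxy enters ortho to a large group, here meta to a large group. Compound 4 is expected to give a step that the limit leaves unreadable from compound 3 to compound 4 in this assay, resting on the unreadable earlier step that the two limits leave unreadable from compound 1 to compound 2 and on the limits at which all measured compounds sit. Compound 4 is therefore estimated at 250000 nM, between 120000 nM and 600000 nM, most likely again reported only as a limit.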

Compound 4, half-maximal cytotoxic concentration: > 220000 nM
Compound 4 was reported as a limit; the forecaster's own chance of this, stated with the estimate: 85%; the middle value lies beyond the limit too.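

In this assay compound 4 gives only a limit, > 220000 nM. No step among compound 1, compound 2, compound 3 and compound 4 can be read, since every value sits at one of two limits: the limit of > 220000 nM in this assay, at which 2 of the 4 values shown sit. The other limit is this: the limit of > 230000 nM in this assay, at which 2 of the 4 values shown sit. The compounds shown leave open how much of each is tolerated in this assay, and whether methoxy in place of methyl changes that at all.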